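Swapping the Benzylamide for a Morpholine Amide

The source may report more compounds than this note shows. Statements on the series, on what has been measured and on what is new or still open speak of the compounds shown alone.

Three compounds share one core and differ only in the group attached to the carbonyl carbon. Compound 1 `Cc1ccsc1C(=CCCN(C)C(CCO)C(=O)NCc1ccccc1)c1sccc1C` gives 5.71 in a physicochemical assay for lipophilicity, read by HPLC; on this read-out lower numbers stand for lower lipophilicity and higher numbers for higher lipophilicity. Compound 2 `Cc1ccsc1C(=CCCN(C)C(CCO)C(=O)NCc1ccc(Cl)cc1)c1sccc1C` gives 6.38 in this assay, and compound 3 `Cc1ccc(CNC(=O)C(CCO)N(C)CCC=C(c2sccc2C)c2sccc2C)cc1` gives 6.2. Compound 3 thus stands second highest of the three: its value and that of compound 2 lie within the scatter of each other, while the step of a number 0.49 log units higher from compound 1 to compound 3 (beyond the scatter) goes beyond it, as does a number 0.67 log units higher from compound 1 to compound 2 (beyond the scatter).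

Compound 4 `Cc1ccsc1C(=CCCN(C)C(CCO)C(=O)N1CCOCC1)c1sccc1C` differs from compound 3 in a larger way: morpholin-4-yl in place of (4-methylbenzyl)amino on a carbonyl carbon. Every measured step here changes only a single substituent on the aromatic ring of the benzyl group; none removes that ring or the amide hydrogen. For the measured compounds named here, no measured step therefore bears directly on this change, and the expectation rests on the scale of the exchange alone. The whole (4-methylbenzyl)amino group leaves and a morpholin-4-yl group enters. Compound 4 is expected to come out well lower, estimated at 4.5 with a range from 3.8 to 5.3, a step of a number 1.70 log units lower from compound 3 to compound 4 (beyond the scatter).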

Compound 4, partition coefficient: 4.75
The estimate for compound 4 lay 0.25 log units below the measured number; measured number inside the range.
By their numbers in this assay, from the lowest: compound 4; then compound 1; then compounds 3 and 2 (each within the scatter of the next).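

Until now only a substituent on the benzyl ring had varied, and here the whole group on the carbonyl carbon is exchanged, which opens a much wider view of this position in this assay. The number falls whichever benzyl compound serves as the starting point: a number 1.45 log units lower from compound 3 to compound 4 (beyond the scatter) and a number 1.63 log units lower from compound 2 to compound 4 (beyond the scatter) and a number 0.96 log units lower from compound 1 to compound 4 (beyond the scatter), so even the plain benzylamino group, with no substituent on its ring, stands clear of morpholin-4-yl. No measurement here says what lies behind this fall.

As far as these compounds go, the exchange removes the aromatic ring and the amide hydrogen and brings in a ring oxygen all at once, so the share of each remains open. A piperidin-1-yl group, which has no oxygen, or a cyclohexylmethylamino group, which keeps the amide hydrogen on a non-aromatic ring, would begin to pull these apart.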